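The compounds below may be only part of what the source reports. "The series", "measured", "known", "first", "only" and "open" are said of these compounds alone.

Three compounds have been measured in a functional assay on HEK293 cells for antagonist activity at transient receptor potential M8 protein (Canis lupus familiaris), read by FLIPR and calcium flux; a higher number here means a weaker inhibitor, a lower number a stronger inhibitor:

compound 1, `FC(F)(F)c1ccccc1-c1ccc2[nH]c(C3=NOC4(CCCCC4)C3)nc2c1`, with 3.1 nM;
compound 2, `Fc1cc(-c2ccccc2C(F)(F)F)cc2nc(C3=NOC4(CCCCC4)C3)[nH]c12`, with 2.2 nM;
compound 3, `FC(F)(F)c1ccccc1-c1cc(Br)c2[nH]c(C3=NOC4(CCCCC4)C3)nc2c1`, with 2.7 nM.

Compound 3 stands second highest of the three numbers in this assay; compound 1 is the nearest and compound 2 the furthest, and both gaps lie within the scatter. Compound 4, `OCCCc1cc(-c2ccccc2C(F)(F)F)cc2nc(C3=NOC4(CCCCC4)C3)[nH]c12`, is not yet measured. It differs from compound 3 in one place: 3-hydroxypropyl in place of bromo on an aromatic carbon. Among the measured compounds shown here, three measured steps touch the same aromatic carbon. The step of a 1.1-fold lower number from compound 1 to compound 3 (0.06 log units; within the scatter), the step of a 1.2-fold higher number from compound 2 to compound 3 (0.09 log units; within the scatter) and the step of a 1.4-fold lower number from compound 1 to compound 2 (0.15 log units; within the scatter) all lie within the scatter, so hydrogen, fluoro and bromo at that position have given much the same number. For the measured compounds named here, no measured compound carries a 3-hydroxypropyl, or any group with a hydrogen-bond donor, at that position, so the data do not show how such a group fares. On that evidence the step expected is a 1.9-fold higher number from compound 3 to compound 4 (0.27 log units; within the scatter), small, with some allowance for a higher number. Compound 4 is therefore estimated at 5 nM, in the range 1.5 nM to 16 nM.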

Compound 4, half-maximal inhibitory concentration: 0.2 nM
The estimate for compound 4 lay 25-fold (1.40 log units) above the measured number; the whole stated range lies above it.
By their numbers in this assay, from the lowest: compound 4; then compounds 2, 3 and 1 (each within the scatter of the next).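

In this assay this aromatic carbon turns out not to be indifferent to what it carries: 3-hydroxypropyl gives a 14-fold lower number from compound 3 to compound 4 (1.13 log units; beyond the scatter) when it replaces bromo, an 11-fold lower number from compound 2 to compound 4 (1.04 log units; beyond the scatter) when it replaces fluoro and a 16-fold lower number from compound 1 to compound 4 (1.19 log units; beyond the scatter) when it replaces hydrogen. Hydrogen, fluoro and bromo stayed within the scatter of one another, so compound 4 is the first to show that a change here can move the number well beyond it, and it is the strongest inhibitor of the four. No measurement shown bears on the reason for this gain.

On these data alone, it remains open whether the gain belongs to the hydroxyl or to the chain itself. A plain propyl group, a shorter or longer chain ending in hydroxyl, or a chain ending in an amine or a carboxylic acid would bear on that question.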